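A few compounds are considered here, and "the series" means these few. Any claim that something is new, unique, unknown or untested is made for them only; others in the source may bear on it.

Compound 1 `CCN(CC)CCCOc1cc2ncnc(Nc3nc4ccc(C(=O)Nc5c(C)cccc5C)cc4s3)c2cc1OC` in a functional assay on DLD-1 cells (Homo sapiens) for cytotoxicity, read by WST assay, with a stated time of 72 h (on this read-out lower numbers stand for stronger inhibition and higher numbers for weaker inhibition), gives > 100000 nM, which is a limit of the assay and not a number.
Compound 2 `COc1cc2c(Nc3nc4ccc(C(=O)Nc5c(C)cccc5C)cc4s3)ncnc2cc1OCCCN1CCCCC1` in this assay gives > 100000 nM, likewise a limit of the assay.

Compound 2 therefore stands only at a limit, with no number of its own. The step that the two limits leave unreadable from compound 1 to compound 2 cannot be sized because both values sit at the limit of > 100000 nM in this assay, at which 2 of the 2 values shown sit. Compound 3 `COc1cc2c(Nc3nc4ccc(C(=O)Nc5c(C)cccc5C)cc4s3)ncnc2cc1OCCCN1CCC(C)CC1` differs from compound 2 by methyl in place of hydrogen on a saturated ring carbon, a methyl in place of hydrogen on a saturated ring carbon. Within the data shown here, with the only measured step unreadable, no step beyond the scatter is expected in this assay, and compound 3 is expected to remain at the limit. The estimate for compound 3 is 100000 nM (30000 nM to 300000 nM), an expected step of a number no higher from compound 2 to compound 3 (the limit leaves the size open).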

Compound 3, half-maximal inhibitory concentration: > 100000 nM
Compound 3 gave a limit, no number (the forecaster's own chance of this, stated with the estimate: 85%); the middle value sits exactly at the limit.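

No step can be read among compound 1, compound 2 and compound 3, because all three values are limits of the assay, not numbers: the limit of > 100000 nM in this assay, at which 3 of the 3 values shown sit.

Still open, going by these compounds, is whether diethylamino, piperidin-1-yl and 4-methylpiperidin-1-yl differ at all in this assay at concentrations beyond this limit.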